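A few compounds are considered here, and "the series" means these few. Any claim that something is new, unique, unknown or untested is made for them only; others in the source may bear on it.

Compound 1, `Cc1ccccc1C(=O)Nc1ccc(C#N)cn1`, was measured in a physicochemical assay for solubility, read by nephelometry, measured as kinetic solubility, at pH 6.5, tested at 10 mg/mL (a higher number here means a more soluble compound, a lower number a less soluble compound), and gave 6.3 ug/mL. Two related compounds sit beside it. Compound 2, `Cc1c(F)cccc1C(=O)Nc1cc(Cl)ccn1`, gives 12.5 ug/mL in this assay, a number that lies within the scatter of compound 1, so the two cannot be told apart. Going by the values given here, compound 3, `Cc1c(C(=O)Nc2ccccn2)ccc(F)c1F`, gives 25 ug/mL, which stands beyond the scatter above compound 1 and is the only number of the three that clearly differs from it.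

Compound 4, `COc1ccc(NC(=O)c2ccccc2C)nc1`, has not yet been measured. Relative to compound 1 its structure changes in one place: methoxy in place of cyano on an aromatic carbon. The group that leaves and the group that enters are both small, each with one hydrogen-bond acceptor and none donated, and no ring is gained or lost.

Among the compounds with values here, no measured pair in this set shows what such a swap does. On that basis compound 4 is expected to stay close to compound 1, with a step of a 1.3-fold higher number from compound 1 to compound 4 (0.10 log units; within the scatter) that is not expected to reach beyond the scatter. The estimate for compound 4 is 8 ug/mL, with a range from 3 ug/mL to 25 ug/mL.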

Compound 4, solubility: 12.5 ug/mL
Estimate against measurement, compound 4: 1.6-fold (0.19 log units) below; measured number inside the range.
By their numbers in this assay, from the lowest: compounds 1, 2, 4 and 3 (each within the scatter of the next, the first and the last beyond it).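

Going by these compounds alone, this is the first pair in the set that differs in one place, and it gives the swap a reading: methoxy in place of cyano on an aromatic carbon, two atoms from the ring nitrogen and para to a large group, comes to a 2.0-fold higher number from compound 1 to compound 4 (0.30 log units; within the scatter) in this assay and so leaves the two compounds indistinguishable. At this position, then, the nitrile can give way to methoxy, with the same count of heavy atoms and hydrogen-bond acceptors, without a step beyond the scatter. Nothing at hand explains this reading.

This single pair leaves open whether the swap would read the same with other groups elsewhere on the shared core. It also leaves open how an amine or a carboxylic acid on this aromatic carbon would read in this assay against these two compounds.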